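A few compounds are considered here, and "the series" means these few. Any claim that something is new, unique, unknown or untested is made for them only; others in the source may bear on it.

Among the three numbers in hand, compound 2 `COc1cc(-c2nn(-c3cccc(NC(=O)c4cccc(C(F)(F)F)c4)c3)cc2-c2ccncc2)ccc1Cl` gives the lowest in a functional assay on MDA-MB-435 cells (Homo sapiens) for inhibition, read by sulforhodamine B assay, with a stated time of 48 h (a lower number here means a stronger inhibitor, a higher number a weaker inhibitor), at 710 nM. Compound 3 `O=C(Nc1cccc(-n2cc(-c3ccncc3)c(-c3ccc(Cl)c(O)c3)n2)c1)Nc1cc(C(F)(F)F)cc(C(F)(F)F)c1` gives 910 nM, which lies within the scatter of compound 2, while compound 1 `O=C(Nc1cccc(-n2cc(-c3ccncc3)c(-c3ccc(Cl)c(O)c3)n2)c1)Nc1cccc(C(F)(F)F)c1` gives 1490 nM, beyond the scatter. Compound 4 `COc1cc(-c2nn(-c3cccc(NC(=O)c4ccccc4)c3)cc2-c2ccncc2)ccc1Cl` differs from compound 2 in one place: hydrogen in place of trifluoromethyl on an aromatic carbon. Going by the values given here, the only measured step touching a trifluoromethyl is a 1.6-fold lower number from compound 1 to compound 3 (0.21 log units; within the scatter), small and within the scatter, and it runs the other way, adding rather than removing the group. On that basis the change should matter little; a small rise in the number is the most that seems warranted. The expected step is a 1.4-fold higher number from compound 2 to compound 4 (0.15 log units; within the scatter). Compound 4 is therefore estimated at 1000 nM, with a range of 400 nM to 2500 nM.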

Compound 4, half-maximal inhibitory concentration: 190 nM
Compound 4: middle estimate off by 5.3-fold (0.72 log units), on the high side; the measured number lies below the stated range.
By their numbers in this assay, from the lowest: compound 4; then compounds 2, 3 and 1 (each within the scatter of the next, the first and the last beyond it).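

In this assay, going from 3-(trifluoromethyl)phenyl to phenyl on the core of compound 2 gives a 3.7-fold lower number from compound 2 to compound 4 (0.57 log units; beyond the scatter), so this position is sensitive to the change on that core. The size of the step depends on the core, and the trifluoromethyl group cannot be read as having one effect across the series: the same change on two cores in this assay, a 1.6-fold lower number (0.21 log units; within the scatter) from compound 1 to compound 3 and a 3.7-fold higher number (0.57 log units; beyond the scatter) from compound 4 to compound 2, 6.1-fold (0.79 log units) apart, beyond the scatter of two such steps

Open, on these data alone, is whether a methyl, a chlorine or a nitrile at this position would sit nearer compound 2 or compound 4. Also open, as far as these compounds go, is whether the core of compound 1 would follow the same direction if its trifluoromethyl gave way to hydrogen.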